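Adding a second methoxy group to a borylated amide series

The source may report more compounds than this note shows. Statements on the series, on what has been measured and on what is new or still open speak of the compounds shown alone.

Measured compounds:
compound 1, `COc1cccc(-c2cccc(NC(=O)CCc3ccc4c(c3)B(O)OC4)c2)c1`, 49000 nM
compound 2, `COc1cc(OC)cc(-c2cccc(NC(=O)CCc3ccc4c(c3)B(O)OC4)c2)c1`, 21000 nM
compound 3, `COc1cccc(-c2cccc(NC(=O)CCc3ccccc3)c2)c1`, 25000 nM

These three compounds were tested in a functional assay on MDA-MB-231 cells (Homo sapiens) for antiproliferative activity, read by MTT assay, with a stated time of 72 h; on this read-out lower numbers stand for stronger inhibition and higher numbers for weaker inhibition. Compound 1 and compound 2 differ by one change, (methoxy in place of hydrogen on an aromatic carbon), and this gave a 2.3-fold lower number from compound 1 to compound 2 (0.37 log units; beyond the scatter). Compound 3 carries a different core; how the core of compound 3 differs from the core of compound 1 is not broken down here. Compound 4, `COc1cc(OC)cc(-c2cccc(NC(=O)CCc3ccccc3)c2)c1`, has not yet been measured; it differs from compound 3 by methoxy in place of hydrogen on an aromatic carbon, the same change that turned compound 1 into compound 2. From compound 3 to compound 4 a step of a 2.3-fold lower number from compound 3 to compound 4 (0.36 log units; beyond the scatter) is expected in this assay, because a 2.3-fold lower number from compound 1 to compound 2 (0.37 log units; beyond the scatter). Compound 4 is therefore estimated at 11000 nM, with a range from 5000 nM to 25000 nM.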

Compound 4, half-maximal inhibitory concentration: 87000 nM
For compound 4 the middle estimate is 7.9-fold (0.90 log units) below the measured one; measured number above the stated range.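

In this assay, adding the methoxy group gives a 3.5-fold higher number from compound 3 to compound 4 (0.54 log units; beyond the scatter), the opposite direction to the step seen on the core of compound 1, so this change does not carry over between these two cores: the same change on two cores in this assay, a 2.3-fold lower number (0.37 log units; beyond the scatter) from compound 1 to compound 2 and a 3.5-fold higher number (0.54 log units; beyond the scatter) from compound 3 to compound 4, 8.1-fold (0.91 log units) apart, beyond the scatter of two such steps

With both methoxy groups present, the core matters as well, since replacing the boron-containing group with the plain aromatic ring gives a 4.1-fold higher number from compound 2 to compound 4 (0.62 log units; beyond the scatter). Within the data shown here, these results show that the effect of the change depends on the core, but with only one pair on each core they do not show why.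

As far as these compounds go, it remains open whether a hydroxyl group or a fluorine atom in the same place would also split between the two cores. From the compounds shown here alone, it is also open how the methoxy change would behave on a third core.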